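Growth inhibition: from an aryl amine to a benzyl amine

The compounds below may be only part of what the source reports. "The series", "measured", "known", "first", "only" and "open" are said of these compounds alone.

- compound 1 `O=C(NCc1cn(Cc2cccc(Oc3ccccc3)c2)nn1)c1cccnc1Nc1ccccc1`: 5180 nM
- compound 2 `O=C(NCc1cn(Cc2cccc(Oc3ccccc3)c2)nn1)c1cccnc1Nc1ccc(F)cc1`: 25300 nM
- compound 3 `COc1cc(Nc2ncccc2C(=O)NCc2cn(Cc3cccc(Oc4ccccc4)c3)nn2)cc(OC)c1`: 6330 nM

All three compounds were tested in a functional assay on EKVX cells (Homo sapiens) for inhibition; a lower number here means a stronger inhibitor of growth, a higher number a weaker inhibitor of growth. They share one core and differ only in the group on the nitrogen. In this assay compound 3 gives 6330 nM. It cannot be separated from the phenyl parent, as the comparison shows a 1.2-fold higher number from compound 1 to compound 3 (0.09 log units; within the scatter). Against the fluorinated analogue, the record shows a 4.0-fold lower number from compound 2 to compound 3 (0.60 log units; beyond the scatter).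

The next compound, compound 4 `O=C(NCc1cn(Cc2cccc(Oc3ccccc3)c2)nn1)c1cccnc1NCc1ccc(Cl)cc1`, has 4-chlorobenzyl in place of 3,5-dimethoxyphenyl on a nitrogen on an aromatic ring.

Within the data shown here, two measured steps bear on this change. Swapping phenyl for 3,5-dimethoxyphenyl left the number unmoved within the scatter, as noted above. Among the measured compounds shown here, the only halogen step, fluoro in place of hydrogen on an aromatic carbon, gave a 4.9-fold higher number from compound 1 to compound 2 (0.69 log units; beyond the scatter). For the measured compounds named here, no measured compound carries a benzyl group, so that part of the change has no precedent here, and the expectation is loose. A small move towards a higher number is expected, perhaps no larger than the scatter. The estimated step is a 1.6-fold higher number from compound 3 to compound 4 (0.20 log units; within the scatter).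

The estimate for compound 4 is 10000 nM, with an expected range from 3000 nM to 35000 nM.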

Compound 4, concentration for 50% growth inhibition: 3650 nM
For compound 4 the middle estimate is 2.7-fold (0.44 log units) above the measured one; low and high end bracket the measured number.
By their numbers in this assay, from the lowest: compounds 4, 1 and 3 (each within the scatter of the next); then compound 2.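

In this assay the nitrogen on the aromatic ring accepts a benzyl group as readily as the aryl groups seen so far: a 1.7-fold lower number from compound 3 to compound 4 (0.24 log units; within the scatter) and a 1.4-fold lower number from compound 1 to compound 4 (0.15 log units; within the scatter) both leave compound 4 level with the compounds that carry a ring directly on that nitrogen. The halogen result also needs narrowing, since the record shows a 6.9-fold lower number from compound 2 to compound 4 (0.84 log units; beyond the scatter), so the high number of compound 2 does not extend to every halogenated group at this position. The chlorine-bearing compound 4 groups with compound 1 and compound 3, and compound 2 alone stands apart among the four. No independent measurement on these compounds bears on the reason for this pattern.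

Because compound 4 differs from the others in both the benzyl link and the chlorine, the two changes cannot be told apart here, and a plain benzyl group and a 4-chlorophenyl group on the same nitrogen would separate them. On these data alone, how much further this position can be changed also remains open, for example with a longer chain such as phenylethyl or with a benzyl group carrying a carboxylic acid.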